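Coumarin propargylamines: dropping the benzyl group

The compounds below may be only part of what the source reports. "The series", "measured", "known", "first", "only" and "open" are said of these compounds alone.

Compound 2 `C#CCN(CCCCOc1ccc2ccc(=O)oc2c1)Cc1ccc(C)cc1` gives 94500 nM in an ADME assay on isolated protein for inhibition of Amine oxidase [flavin-containing] A (Homo sapiens), read by fluorescence and Amplex Red, with stated times of 15 min and 20 min (a higher number here means a weaker inhibitor, a lower number a stronger inhibitor), the second highest of the three numbers. Compound 1 `C#CCN(CCCOc1ccc2ccc(=O)oc2c1)Cc1ccc(C)cc1` gives 116000 nM, within the scatter of compound 2, while compound 3 `C#CCN(CCCOc1ccc2ccc(=O)oc2c1)Cc1cccc(OC)c1` gives 22700 nM, beyond it. Compound 4 `C#CCN(C)CCCCOc1ccc2ccc(=O)oc2c1` differs from compound 2 by hydrogen in place of 4-methylphenyl on a saturated chain carbon bound to an amine nitrogen. Going by the values given here, the only measured step, a 5.1-fold lower number from compound 1 to compound 3 (0.71 log units; beyond the scatter), exchanges one arene for another and so bears only loosely on removing the arene altogether; no measured pair drops the benzyl group. The account therefore expects a step of a 1.6-fold higher number from compound 2 to compound 4 (0.20 log units; within the scatter) that is uncertain in direction, and compound 4 is estimated at 150000 nM, between 30000 nM and 600000 nM.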

Compound 4, half-maximal inhibitory concentration: 3280 nM
Compound 4: middle estimate off by 46-fold (1.66 log units), on the high side, and the stated range ends above it.
By their numbers in this assay, from the lowest: compound 4; then compound 3; then compounds 2 and 1 (each within the scatter of the next).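

In this assay, the change from 4-methylbenzyl to methyl gives a 29-fold lower number from compound 2 to compound 4 (1.46 log units; beyond the scatter), a large step. Compounds 1, 2 and 3 all carry an arene at this position, so they could show only that one arene differs from another; compound 4 shows that inhibition here does not depend on having an arene at this position at all. No measurement shown explains the size of this step.

From the compounds shown here alone, it remains open whether ethyl or cyclopropyl in place of that methyl would hold this gain. Also open, going by these compounds, is whether 4-methylbenzyl to methyl gives a similar step on the chain of compound 1.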